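This account rests on a few compounds, and the source may have more. Where it says the series, first, only, none or still open, it means among the compounds named here.

In a functional assay on the whole organism (Myocardium) with Canis familiaris (Canis lupus familiaris) as the target, at a dose of 8.75 mg/kg by the intravenous route (a lower number here means that less compound is needed, a higher number that more compound is needed for the effect), compound 3 `CCc1nc(O)nc2cc(OC)c(OC)cc12` gives 3.4 mg/kg and compound 1 `Cc1nc(O)nc2ccccc12` gives 3.45 mg/kg which is level with it within the usual scatter. Compound 2 `COc1ccc(OC)c2c(C)nc(O)nc12` gives 8.75 mg/kg as a clearly higher number than compound 3 shows, so more of compound 2 is needed for the effect. Compound 4 `COc1cc2nc(O)nc(C3CCCC3)c2cc1OC` has not been measured yet. Compared with compound 3, it carries cyclopentyl in place of ethyl on an aromatic carbon and the rest of the structure stays the same. Going by the values given here, no measured pair shows a change at this place, so no step beyond the scatter is expected, in either direction. The estimated step of a 1.2-fold higher number from compound 3 to compound 4 (0.07 log units; within the scatter) is small and remains uncertain. The expected value for compound 4 is 4 mg/kg within an estimated range of 1.7 mg/kg to 9 mg/kg for this measurement.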

Compound 4, dose for half-maximal effect: > 8.75 mg/kg
Compound 4: a limit, no number (the forecaster's own chance of this, stated with the estimate: 3%); middle value at least 2.1-fold (0.33 log units) from the limit.
By their numbers in this assay, from the lowest: compounds 3 and 1 (each within the scatter of the next); then compound 2.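

This is the first change shown at this position, on an aromatic carbon next to the ring nitrogen, and it is not neutral: cyclopentyl in place of ethyl gives an at least 2.5-fold higher number from compound 3 to compound 4 (0.41 log units; beyond the scatter) in this assay. For compound 4 the result of > 8.75 mg/kg is a limit of the assay and not a number. In this one pair, more compound is needed with cyclopentyl than with ethyl at this place.

Still open, from the compounds shown here alone, is whether the ring itself or simply the extra carbon atoms matter. A longer chain such as butyl at this place could separate the two, and an amine there would show how a group containing nitrogen compares.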